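The compounds below may be only part of what the source reports. "The series", "measured", "known", "first", "only" and "open" are said of these compounds alone.

Compound 1 `CCc1cc(C(C)=O)c(O)cc1OCCCCC#N` gives 92% in an assay on isolated protein for inhibition of leukotriene B4 receptor 1 (Homo sapiens), tested at 10 uM (a lower number here means less inhibition, a higher number more inhibition at the concentration tested (going by the name of the read-out)), the highest of the three numbers recorded there. Compound 2 `CC(=O)c1cc(C=O)c(OCCCCC#N)cc1O` gives 6% in this assay, and compound 3 `CC(=O)c1cc(C(C)=O)c(OCCCCC#N)cc1O` gives 8%. The two steps away from compound 1 are both large: a number 86 percentage points lower from compound 1 to compound 2 (beyond the scatter) and a number 84 percentage points lower from compound 1 to compound 3 (beyond the scatter). Between the two compounds with the lower numbers the step of a number 2 percentage points higher from compound 2 to compound 3 (within the scatter) is small.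

Compound 4 `CCc1cc(C(C)=O)c(O)cc1OCCCCc1nnn[nH]1` differs from compound 1 at the end of the chain: 1H-tetrazol-5-yl in place of cyano on a saturated chain carbon, four bonds along the chain from an oxygen on an aromatic ring. For the measured compounds named here, neither measured step bears on this change, since both alter the substituent on the aromatic carbon and leave the chain end untouched, while the chain end is the only part that changes from compound 1 to compound 4. The data therefore give no direct guide to the size or direction of the step. On that basis a modest step downward is expected, a number 22 percentage points lower from compound 1 to compound 4 (beyond the scatter), with wide uncertainty. Compound 4 is estimated to give 70% in this assay, within a range from 30% to 95%.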

Compound 4, a percentage reported as inhibition, at one concentration (the size of the read-out at that concentration, not a potency): 49%
Compound 4: the middle estimate sits 21 percentage points above what was measured; measured number inside the range.
By their numbers in this assay, from the lowest: compounds 2 and 3 (each within the scatter of the next); then compound 4; then compound 1.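

Placing 1H-tetrazol-5-yl in place of cyano on a saturated chain carbon, four bonds along the chain from an oxygen on an aromatic ring, gives a number 43 percentage points lower from compound 1 to compound 4 (beyond the scatter) in this assay, the first sign that the chain end, and not only the substituent on the aromatic carbon, bears on this number. The nitrile is nonetheless not the only chain end that retains a measurable read-out, as compound 4 still gives 49%. No measurement at hand accounts for the size of this step.

From the compounds shown here alone, it remains open how a carboxylic acid or a primary amide at the same chain end would compare with the nitrile and the tetrazole. A longer chain carrying the tetrazole is equally unresolved, as is the effect of this exchange with the acetyl group of compound 3 in place of ethyl.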